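The source may hold more compounds than are shown below. What is called first, only, known or untested is meant among the compounds shown, and "the series" means these compounds.

Of the compounds shown here, three that share one core have been tested in an assay on isolated protein for inhibition of Caspase-8 (Homo sapiens); on this read-out higher numbers stand for an effect only at larger amounts of compound and lower numbers for an effect already at smaller amounts. Compound 1 `O=C1C(=O)N(Cc2ccc(F)cc2)c2ccc(S(=O)(=O)N3CCCC3)cc21` carries the plain saturated ring, and in this assay compound 1 gives > 5000 nM, which is a limit of the assay rather than a number. Compound 2 `O=C1C(=O)N(Cc2ccc(F)cc2)c2ccc(S(=O)(=O)N3CCC[C@H]3COc3ccc(F)cc3F)cc21` carries a (2,4-difluorophenoxy)methyl group on a saturated ring carbon, and in this assay compound 2 gives > 5000 nM, again only a limit. Compound 3 `O=C1C(=O)N(Cc2ccc(F)cc2)c2ccc(S(=O)(=O)N3CCC[C@H]3COc3ccncn3)cc21` carries a ((pyrimidin-4-yl)oxy)methyl group in that place, and compound 3 gives > 5000 nM, also a limit. Compound 2 thus sits at the limit of > 5000 nM in this assay, at which 3 of the 3 values shown sit, with no number of its own to compare. For the same reason the steps a step that the two limits leave unreadable from compound 1 to compound 2, a step that the two limits leave unreadable from compound 1 to compound 3 and a step that the two limits leave unreadable from compound 2 to compound 3 cannot be read.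

Compound 4 `C#CCN1C(=O)C(=O)c2cc(S(=O)(=O)N3CCC[C@H]3COc3ccc(F)cc3F)ccc21` differs from compound 2 by ethynyl in place of 4-fluorophenyl on a saturated chain carbon bound to an amide-type nitrogen in a ring. Among the compounds with values here, no measured step covers a change of this kind, so nothing in the data points toward a step in either direction. The expectation is that compound 4 also reaches only the limit. The estimate for compound 4 is 10000 nM, with a range from 3000 nM to 50000 nM. The step expected from this is a step that the limit leaves unreadable from compound 2 to compound 4.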

Compound 4, half-maximal effective concentration: > 5000 nM
Compound 4: only a limit was reported; the forecaster's own chance of this, stated with the estimate: 85%; the middle value does not contradict the limit.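

In this assay compound 4 gives > 5000 nM as a limit and not a number, so the step from compound 2 to compound 4 cannot be read, and compound 4 adds no comparison: (the limit of > 5000 nM in this assay, at which 4 of the 4 values shown sit). The compounds shown leave open which change to the shared core, if any, would give this assay a real number instead of a limit.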